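The source may report more compounds than this note shows. Statements on the series, on what has been measured and on what is new or still open speak of the compounds shown alone.

Measured so far:
compound 1, `O=C(Cc1ccc(F)cc1)c1sc2ncccc2c1-c1ccc(F)cc1`: 140 nM
compound 2, `COc1ccc(CCC(=O)c2sc3ncccc3c2-c2ccccc2)cc1`: 2500 nM
compound 3, `O=C(OCc1ccc(F)cc1)c1sc2ncccc2c1-c1ccc(Cl)cc1`: 41 nM

These three values come from an assay on cell membranes for displacement of a labelled ligand from metabotropic glutamate receptor 5 (Rattus norvegicus); a lower number here means a stronger inhibitor, a higher number a weaker inhibitor. Among them compound 1 holds the second highest number: compound 3 sits at a lower number, beyond the scatter, and compound 2 at a much higher one, also beyond the scatter. Compound 4 `O=C(NCc1ccc(F)cc1)c1sc2ncccc2c1-c1ccc(F)cc1` has not yet been measured. It differs from compound 1 in one place: (4-fluorobenzyl)amino in place of 4-fluorobenzyl on a carbonyl carbon. Among the compounds with values here, no measured pair shows this exact change, so the step is uncertain. Because compound 3 gives 41 nM with a different link at the same carbonyl, a change there is not expected to cost much, and from compound 1 to compound 4 a step of a 1.4-fold higher number from compound 1 to compound 4 (0.15 log units; within the scatter) is expected, possibly none beyond the scatter. Compound 4 is estimated at 200 nM, within 50 nM to 800 nM.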

Compound 4, inhibition constant: 311 nM
Compound 4: the middle estimate sits 1.6-fold (0.19 log units) below what was measured; measured number inside the range.
By their numbers in this assay, from the lowest: compound 3; then compound 1; then compound 4; then compound 2.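

In this assay the change from 4-fluorobenzyl to (4-fluorobenzyl)amino on the carbonyl carbon gives a 2.2-fold higher number from compound 1 to compound 4 (0.35 log units; beyond the scatter) and so is a modest loss, beyond the scatter. This first single-place comparison shows that this position responds to a small change: one added nitrogen carrying one hydrogen-bond donor. Nothing here explains the loss.

The compounds shown leave open whether the amide hydrogen itself matters, which a methyl group on that nitrogen would test. They also leave open how an ether oxygen in place of that nitrogen would compare on an otherwise identical compound.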